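A few compounds are considered here, and "the series" means these few. Any claim that something is new, unique, unknown or untested is made for them only; others in the source may bear on it.

Measured so far in an ADME assay on microsomes from liver (Homo sapiens) for metabolic stability, tested at 2.5 uM; on this read-out higher numbers stand for fast clearance and lower numbers for slow clearance:
- compound 1, `COc1ccc(S(=O)(=O)c2cnc3cc(F)ccc3c2-c2ccc(F)cc2)cc1Cl`: 1.29 mL/min
- compound 2, `COc1ccc(S(=O)(=O)c2cnc3cc(F)ccc3c2-c2cccc(Cl)c2)cc1Cl`: 1.19 mL/min
- compound 3, `Cc1ccc(S(=O)(=O)c2cnc3cc(F)ccc3c2-c2ccc(F)cc2)cc1F`: 2.33 mL/min

Compounds 1 and 2 share a core and differ only by 3-chlorophenyl in place of 4-fluorophenyl on an aromatic carbon. The step in this assay is a 1.1-fold lower number from compound 1 to compound 2 (0.04 log units; within the scatter). Compounds 1 and 3 differ in the sulfonyl substituent, (3-fluoro-4-methylphenyl in place of 3-chloro-4-methoxyphenyl on a sulfonyl sulfur), with a step of a 1.8-fold higher number from compound 1 to compound 3 (0.26 log units; within the scatter). Among the measured compounds shown here, no step is recorded between compounds 2 and 3; their two values sit within the scatter of one another.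

Compound 4, `Cc1ccc(S(=O)(=O)c2cnc3cc(F)ccc3c2-c2cccc(Cl)c2)cc1F`, has not yet been measured. It carries the core of compound 3 and differs from it by 3-chlorophenyl in place of 4-fluorophenyl on an aromatic carbon. The place lines of this change and of the change from compound 1 to compound 2 agree word for word, so the two changes are the same. The expectation for this assay therefore rests on the earlier pair: because a 1.1-fold lower number from compound 1 to compound 2 (0.04 log units; within the scatter) lay within the scatter, the step is estimated as a 1.1-fold lower number from compound 3 to compound 4 (0.05 log units; within the scatter), essentially a flat move from compound 3. Compound 4 is thus expected to give 2.1 mL/min, with a plausible range from 1.2 mL/min to 3.8 mL/min.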

Compound 4, intrinsic clearance in a liver preparation (reported as CLH), per the amount of preparation that the assay uses: 2.13 mL/min
Compound 4: the middle estimate sits 1.0-fold (0.01 log units) below what was measured; measured number inside the range.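

In this assay, 3-chlorophenyl in place of 4-fluorophenyl gives a 1.1-fold lower number from compound 3 to compound 4 (0.04 log units; within the scatter), and this step matches the one seen on the other core: the same change on two cores in this assay, a 1.1-fold lower number (0.04 log units; within the scatter) from compound 1 to compound 2 and a 1.1-fold lower number (0.04 log units; within the scatter) from compound 3 to compound 4, 1.0-fold (0.00 log units) apart, within the scatter of two such steps. The sulfonyl change, 3-fluoro-4-methylphenyl in place of 3-chloro-4-methoxyphenyl, gives a 1.8-fold higher number from compound 2 to compound 4 (0.25 log units; within the scatter), and it too carries over from one core to the other: the same change on two cores in this assay, a 1.8-fold higher number (0.26 log units; within the scatter) from compound 1 to compound 3 and a 1.8-fold higher number (0.25 log units; within the scatter) from compound 2 to compound 4, 1.0-fold (0.00 log units) apart, within the scatter of two such steps. Across these four compounds, each change can therefore be read as transferable, but every step lies within the scatter, so the agreement shows only that neither change produced a step distinguishable from repeat measurement on either core, not that a larger effect would transfer in the same way or that other groups would behave alike.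

As far as these compounds go, all four compounds carry a halogen-substituted phenyl on the aromatic carbon and a substituted phenyl on the sulfonyl sulfur, so it remains open whether an amine, a carboxylic acid or a longer chain at either place would give a step beyond the scatter. Also open, from the compounds shown here alone, is whether such a step would carry from one core to the other as these two changes do.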